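Phenyl for methyl across two cores

The source may hold more compounds than are shown below. What is called first, only, known or untested is meant among the compounds shown, and "the series" means these compounds.

Compound 1 `CO[C@@H]1CC=C2NN(c3cc4ccccc4[nH]3)C(=O)C[C@]2(C)O1` and compound 3 `CO[C@@H]1CC=C2NN(c3cncnc3)C(=O)C[C@]2(C)O1` share most of their skeleton but carry different groups on the ring nitrogen; the difference between the two cores is not broken down here. In a functional assay on SK-N-SH cells (Homo sapiens) for inhibition, read by sulforhodamine B assay, with a stated time of 48 h (on this read-out higher numbers stand for weaker inhibition and lower numbers for stronger inhibition), compound 1 gives 19500 nM and compound 3 gives 16600 nM, two numbers that sit within the scatter of each other.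

Compound 2 `CO[C@@H]1CC=C2NN(c3cc4ccccc4[nH]3)C(=O)C[C@]2(c2ccccc2)O1` differs from compound 1 by one change, (phenyl in place of methyl on a saturated ring carbon). In this assay compound 2 gives 9100 nM, which is a 2.1-fold lower number from compound 1 to compound 2 (0.33 log units; beyond the scatter). Compound 2 and compound 3 also lie within the scatter of one another, so no order between them is claimed.

Compound 4 `CO[C@@H]1CC=C2NN(c3cncnc3)C(=O)C[C@]2(c2ccccc2)O1` is not yet measured. It differs from compound 3 by phenyl in place of methyl on a saturated ring carbon, the same change as that between compound 1 and compound 2, made at the same place on the same saturated ring carbon; only the group on the ring nitrogen differs between the two pairs. With a single prior example of this change, the expectation rests on that one step alone: the step from compound 3 to compound 4 is estimated as a 2.0-fold lower number from compound 3 to compound 4 (0.29 log units; within the scatter), set to mirror a 2.1-fold lower number from compound 1 to compound 2 (0.33 log units; beyond the scatter). On that basis compound 4 is expected to give about 8500 nM in this assay, with a likely range from 4200 nM to 17000 nM. Whether the second core carries the change the same way is the open question that the measurement of compound 4 will answer.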

Compound 4, half-maximal inhibitory concentration: 8200 nM
Compound 4: the middle estimate sits 1.0-fold (0.02 log units) above what was measured; low and high end bracket the measured number.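

Phenyl in place of methyl on a saturated ring carbon carries over from one core to the other in this assay, where the second core gives a 2.0-fold lower number from compound 3 to compound 4 (0.31 log units; beyond the scatter) and the two steps agree: the same change on two cores in this assay, a 2.1-fold lower number (0.33 log units; beyond the scatter) from compound 1 to compound 2 and a 2.0-fold lower number (0.31 log units; beyond the scatter) from compound 3 to compound 4, 1.1-fold (0.02 log units) apart, within the scatter of two such steps.

With phenyl on both cores, pyrimidin-5-yl in place of 1H-indol-2-yl on an amide-type nitrogen in a ring gives a 1.1-fold lower number from compound 2 to compound 4 (0.05 log units; within the scatter) and sets no order between these two groups in the phenyl compounds. Among the compounds shown here, this agreement rests on only two matched pairs, each with a modest step, so it supports transfer between these two cores and gives no rule for other groups on the ring nitrogen, nor any explanation for the size of the step.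

The compounds shown leave open how this saturated ring carbon responds to groups other than methyl and phenyl, such as ethyl, benzyl or a chain ending in a carboxylic acid. They also leave open whether the same step holds with a chain ending in an amine on the ring nitrogen, or with a hydroxyl group in place of the methoxy group.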